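Hydroxyl placement across the shared core

This account rests on a few compounds, and the source may have more. Where it says the series, first, only, none or still open, it means among the compounds named here.

Compound 1 `Oc1cccc(-c2cc(-c3cccc(C(F)(F)F)c3)cc(-c3cccc(O)c3)n2)c1` bears two 3-hydroxyphenyl groups. In a functional assay on DU-145 cells (Homo sapiens) for inhibition (a lower number here means a stronger inhibitor, a higher number a weaker inhibitor), compound 1 gives only a limit of > 50000 nM. Compound 2 `Oc1ccc(-c2cc(-c3cccc(C(F)(F)F)c3)cc(-c3cccc(O)c3)n2)cc1` differs by 4-hydroxyphenyl in place of 3-hydroxyphenyl on an aromatic carbon and in this assay compound 2 gives 11100 nM, so the step is an at least 4.5-fold lower number from compound 1 to compound 2 (0.65 log units; beyond the scatter). Compound 3 `Oc1ccc(-c2cc(-c3cccc(OC(F)(F)F)c3)cc(-c3cccc(O)c3)n2)cc1` gives 5670 nM in this assay, a step of a 2.0-fold lower number from compound 2 to compound 3 (0.29 log units; within the scatter). The difference between the cores of compound 1 and compound 3 is not broken down here. Compound 4 `Oc1ccc(-c2cc(-c3cccc(OC(F)(F)F)c3)cc(-c3ccc(O)cc3)n2)cc1` carries 4-hydroxyphenyl in place of 3-hydroxyphenyl on an aromatic carbon. This is the same kind of change as before, but the place differs: here it sits meta to a 4-hydroxyphenyl group and meta to a large group, rather than meta to a 3-(trifluoromethyl)phenyl group and a 3-hydroxyphenyl group. Among the compounds with values here, the expected step is a 2.8-fold lower number from compound 3 to compound 4 (0.45 log units; beyond the scatter), resting on the single earlier step of an at least 4.5-fold lower number from compound 1 to compound 2 (0.65 log units; beyond the scatter), which starts from a limit and so only bounds the size. Compound 4 is expected near 2000 nM, likely between 500 nM and 6000 nM.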

Compound 4, half-maximal inhibitory concentration: > 50000 nM
Compound 4 was reported as a limit; the forecaster's own chance of this, stated with the estimate: 2%; middle value at least 25-fold (1.39 log units) from the limit.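

In this assay, the change from 3-hydroxyphenyl to 4-hydroxyphenyl on the core of compound 3 gives an at least 8.8-fold higher number from compound 3 to compound 4 (0.94 log units; beyond the scatter). The change therefore does not carry over from the core of compound 1, and its direction is reversed: the same change on two cores in this assay, an at least 4.5-fold lower number (0.65 log units; beyond the scatter) from compound 1 to compound 2 and an at least 8.8-fold higher number (0.94 log units; beyond the scatter) from compound 3 to compound 4, at least 39-fold (1.59 log units) apart, beyond the scatter of two such steps

Both steps involve a limit, so they bound the sizes only, and they do not show which difference between the two cores turns the step: the limit of > 50000 nM in this assay, at which 2 of the 4 values shown sit.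

As far as these compounds go, it remains open whether the reversal goes with the 4-hydroxyphenyl group already on the core, with the trifluoromethoxy group, or with both together. From the compounds shown here alone, how an amine or a carboxylic acid in place of the hydroxyl would read in this assay also remains open.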